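The source may report more compounds than this note shows. Statements on the series, on what has been measured and on what is new or still open speak of the compounds shown alone.

Measured compounds: compound 1 `c1ccc2c(c1)CCC2NC1CCN(CCCc2c[nH]c3ccc(-n4cnnc4)cc23)CC1` with 68%; compound 2 `C[C@@H](NC1CCN(CCCc2c[nH]c3ccc(-n4cnnc4)cc23)CC1)c1ccccc1` with 90%; compound 3 `CN(Cc1ccccc1)CC1CCN(CCCc2c[nH]c3ccc(-n4cnnc4)cc23)CC1` with 93%, all in a functional assay on CHO cells for activation of 5-hydroxytryptamine receptor 1D (Homo sapiens), read by GTPgammaS binding; on this read-out higher numbers stand for larger maximal responses and lower numbers for smaller maximal responses.

Compound 1 gives the lowest of the three numbers in this assay: the nearest is a number 22 percentage points higher from compound 1 to compound 2 (beyond the scatter) and the furthest is a number 25 percentage points higher from compound 1 to compound 3 (beyond the scatter). Compound 4 `c1ccc2c(c1)CCC2NCC1CCN(CCCc2c[nH]c3ccc(-n4cnnc4)cc23)CC1` differs from compound 1 by ((2,3-dihydro-1H-inden-1-yl)amino)methyl in place of (2,3-dihydro-1H-inden-1-yl)amino on a saturated ring carbon. The step that bears most on this change is a number 25 percentage points higher from compound 1 to compound 3 (beyond the scatter), which also moves the amine out onto a methyl on the same ring carbon, though with a different group; a number 3 percentage points higher from compound 2 to compound 3 (within the scatter) shows that this kind of extension alone did little. Going by the values given here, no step here keeps the indanyl while inserting the methyl, so the expectation is tentative: a modest rise of a number 12 percentage points higher from compound 1 to compound 4 (beyond the scatter) is expected, giving compound 4 an estimated 80% with a range of 65% to 95%.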

Compound 4, largest response reached (reported as efficacy), in percent of the reference or control that the assay uses: 78%
For compound 4 the middle estimate is 2 percentage points above the measured one; low and high end bracket the measured number.
By their numbers in this assay, from the lowest: compounds 1 and 4 (each within the scatter of the next); then compounds 2 and 3 (each within the scatter of the next).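

In this assay, lengthening by a methyl while keeping the 2,3-dihydro-1H-inden-1-yl group gives a number 10 percentage points higher from compound 1 to compound 4 (within the scatter), so this extension on the saturated ring carbon does not by itself separate the two compounds. With the methyl in place, the group on the amine still matters, with a number 15 percentage points lower from compound 3 to compound 4 (beyond the scatter) and a number 12 percentage points lower from compound 2 to compound 4 (beyond the scatter). Nothing measured here explains these steps.

The compounds shown leave open how a methyl on the amine nitrogen of compound 4 would read in this assay. They also leave open the effect of an ethyl chain in place of the methyl link.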